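The compounds below may be only part of what the source reports. "The series", "measured", "known", "first", "only" and "open" are said of these compounds alone.

Measured in an ADME assay on MCF-10A cells (Homo sapiens) for antiproliferative activity, read by MTT assay, with a stated time of 72 h; a lower number here means a stronger inhibitor, a higher number a weaker inhibitor:

- compound 1 `S=C(SSC1CCCCC1)N1CCCC1` gives > 10000 nM as a limit
- compound 2 `CCN(CC)C(=S)SSC(C)C` gives > 10000 nM as a limit
- compound 3 `CCCCSSC(=S)N1CCCCC1` gives > 10000 nM as a limit

Compound 1 has no exact figure in this assay, only the limit > 10000 nM as its reading. The whole set looks the same, with the limit of > 10000 nM in this assay, at which 3 of the 3 values shown sit, so the three compounds cannot be placed in any order.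

The next compound to be read is compound 4 `CCN(CC)C(=S)SSC1CCCCC1`. It keeps the core of compound 1 and changes one group on a thiocarbonyl carbon, with diethylamino in place of pyrrolidin-1-yl (diethylamino in place of pyrrolidin-1-yl on a thiocarbonyl carbon). Going by the values given here, no pair of measured compounds differs in one place only, so no measured step can size this exchange directly. Compound 2 also carries diethylamino on a thiocarbonyl carbon, and compound 2 reads > 10000 nM, which is again a limit.

On that basis, no step beyond the usual scatter is expected in this assay, in either direction. The expected change is a step that the limit leaves unreadable from compound 1 to compound 4, an estimate and not a measurement. Compound 4 is estimated at 12000 nM, with an expected range from 5000 nM to 30000 nM, and it may well be reported only as a limit.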

Compound 4, half-maximal inhibitory concentration: > 10000 nM
Compound 4: a limit, no number; the forecaster's own chance of this, stated with the estimate: 75%; the middle value does not contradict the limit.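

In this assay compound 4 gives > 10000 nM, which is a limit and not a number. Compound 1 gives > 10000 nM, also a limit, so no step can be read between compound 1 and compound 4: the limit of > 10000 nM in this assay, at which 4 of the 4 values shown sit. The compounds shown leave open whether diethylamino and pyrrolidin-1-yl on a thiocarbonyl carbon differ at all in this measure.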